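A few compounds are considered here, and "the series" means these few. Any claim that something is new, unique, unknown or untested is made for them only; others in the source may bear on it.

Compound 1, `Nc1sc(-c2ccc(Cl)cc2)c(-c2ccc(Cl)cc2)c1C(=O)N1CCNCC1`: 1020 nM
Compound 2, `Nc1sc(-c2ccc(Cl)cc2)c(-c2ccc(Cl)cc2)c1C(=O)NCc1ccccc1`: 16300 nM
Compound 3, `Nc1sc(-c2ccc(Cl)cc2)c(-c2ccc(Cl)cc2)c1C(=O)N1CCCCC1=O`: 1820 nM

All three were measured in a functional assay on A549 cells (Homo sapiens) for inhibition, read by sulforhodamine B assay, with a stated time of 72 h; a lower number here means a stronger inhibitor, a higher number a weaker inhibitor. Compound 1 gives the lowest of the three numbers. Its nearest neighbour is compound 3, and the step of a 1.8-fold higher number from compound 1 to compound 3 (0.25 log units; within the scatter) lies within the scatter, so these two cannot be ordered. The furthest is compound 2, reached by the step of a 16-fold higher number from compound 1 to compound 2 (1.20 log units; beyond the scatter).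

The unmeasured compound 4, `CC1CCN(C(=O)c2c(N)sc(-c3ccc(Cl)cc3)c2-c2ccc(Cl)cc2)CC1`, differs from compound 1 in one place: 4-methylpiperidin-1-yl in place of piperazin-1-yl on a carbonyl carbon. Among the measured compounds shown here, the measured step that bears most on this change is the one from compound 1 to compound 3, where the piperazin-1-yl group was also exchanged on the same carbonyl carbon for a six-membered ring with 0 hydrogen-bond donors, and that step stayed within the scatter. The large step from compound 1 to compound 2 involved a different kind of change, to benzylamino, and compound 4 keeps a six-membered ring on the carbonyl carbon. The expected step is therefore small, a 1.8-fold higher number from compound 1 to compound 4 (0.25 log units; within the scatter), not clearly beyond the scatter and if anything toward a somewhat higher number. Compound 4 is estimated at 1800 nM in this assay, with a range from 700 nM to 5000 nM.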

Compound 4, half-maximal inhibitory concentration: 1750 nM
For compound 4 the middle estimate is 1.0-fold (0.01 log units) above the measured one; the range from low to high includes it.
By their numbers in this assay, from the lowest: compounds 1, 4 and 3 (each within the scatter of the next); then compound 2.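

In this assay, 4-methylpiperidin-1-yl, with 0 hydrogen-bond donors and 0 hydrogen-bond acceptors, can stand on this carbonyl carbon in place of piperazin-1-yl, with 1 of each, and the two compounds cannot be told apart (the step is a 1.7-fold higher number from compound 1 to compound 4 (0.23 log units; within the scatter)). The ring carbonyl of 2-oxopiperidin-1-yl also makes no readable difference against 4-methylpiperidin-1-yl (the step is a 1.0-fold lower number from compound 3 to compound 4 (0.02 log units; within the scatter)), so compounds 1, 3 and 4 form one group despite their different six-membered rings. Compound 2, with benzylamino, now stands apart from a third compound that carries a ring on this carbonyl carbon (the step is a 9.3-fold lower number from compound 2 to compound 4 (0.97 log units; beyond the scatter)), and it is the only one of the four with an open benzylamino group.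

Compound 2 changes the ring and adds an amide hydrogen in one exchange, so the compounds shown do not separate those two differences, and diethylamino on the same carbonyl carbon, or a piperidine ring carrying a carboxylic acid, remains open. Nothing given here accounts for the gap between compound 2 and the other three.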